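The compounds below may be only part of what the source reports. "The series", "measured", "known", "first", "only" and "open" are said of these compounds alone.

Compound 1 `Nc1ccccc1NC(=O)c1ccc(CSC(=S)N2CCN(Cc3ccccn3)CC2)cc1` gives 23.4% in a functional assay on MGC-803 cells (Homo sapiens) for antiproliferative activity, read by CCK-8 assay, with a stated time of 72 h, tested at 2 uM; on this read-out higher numbers stand for a stronger effect at the one concentration tested and lower numbers for a weaker effect; compound 2 `Nc1ccccc1NC(=O)c1ccc(CSC(=S)N2CCN(c3cccnc3)CC2)cc1` gives 27.6% in this assay; compound 3 `Nc1ccccc1NC(=O)c1ccc(CSC(=S)N2CCc3cc(Cl)ccc32)cc1` gives 57.7% in this assay.

Compound 3 stands highest of the three, beyond the scatter above compound 1 and compound 2. Compound 4 `CN1CCN(C(=S)SCc2ccc(C(=O)Nc3ccccc3N)cc2)CC1` differs from compound 3 by 4-methylpiperazin-1-yl in place of 5-chloro-2,3-dihydro-1H-indol-1-yl on a thiocarbonyl carbon. Going by the values given here, the only measured step, a number 4.2 percentage points higher from compound 1 to compound 2 (within the scatter), changes a group on a piperazine ring and stays within the scatter, so it says little about exchanging the whole ring on the thiocarbonyl carbon. Compound 4 carries a piperazine ring like compound 1 and compound 2, whose values lie well below that of compound 3. In this assay compound 4 is therefore expected to fall back toward those two, a step of a number 31.7 percentage points lower from compound 3 to compound 4 (beyond the scatter). The estimate for compound 4 is 26%, ranging from 10% to 45%.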

Compound 4, a percentage reported as inhibition, at one concentration (the size of the read-out at that concentration, not a potency): 29.6%
Beside the measured number, compound 4's estimate is 3.6 percentage points below it, within the range that was stated.
By their numbers in this assay, from the lowest: compounds 1, 2 and 4 (each within the scatter of the next); then compound 3.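

In this assay, 4-methylpiperazin-1-yl in place of 5-chloro-2,3-dihydro-1H-indol-1-yl on the thiocarbonyl carbon gives a number 28.1 percentage points lower from compound 3 to compound 4 (beyond the scatter), the first sign that exchanging the whole group at this position changes the read-out. Among the piperazines, the other group on the ring makes no clear difference: methyl in place of pyridin-3-yl gives a number 2 percentage points higher from compound 2 to compound 4 (within the scatter), and hydrogen in place of pyridin-2-yl on the chain carbon gives a number 6.2 percentage points higher from compound 1 to compound 4 (within the scatter). No measurement shown here explains the gap.

On these data alone, it remains open whether the chlorine or the rest of 5-chloro-2,3-dihydro-1H-indol-1-yl accounts for the higher number. A bromine or a methoxy group in place of that chlorine, or a morpholine ring on the thiocarbonyl carbon, would help separate the two.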